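Shortening the Side Chain: Compound 1 to Compound 4

The source may hold more compounds than are shown below. What is called first, only, known or untested is meant among the compounds shown, and "the series" means these compounds.

Compound 1 `CCCCC[C@H](C(C)C)C(c1ccc(O)c(OC)c1)c1ccc(O)c(OC)c1` gives 9200 nM in a functional assay on HeLa cells (Homo sapiens) for cytotoxicity, read by WST assay, with a stated time of 48 h; on this read-out higher numbers stand for weaker inhibition and lower numbers for stronger inhibition.
Compound 2 `COc1cc(C(c2ccc(O)c(OC)c2)[C@H](C)[C@H](C)CF)ccc1O` gives 75000 nM in this assay.
Compound 3 `COC[C@@H](C)[C@@H](C)C(c1ccc(O)c(OC)c1)c1ccc(O)c(OC)c1` gives > 100000 nM in this assay, and this is a limit of the assay rather than a number.

Among the numbers shown, compound 1 stands lowest; its nearest neighbour is compound 2, with an 8.2-fold higher number from compound 1 to compound 2 (0.91 log units; beyond the scatter). The remaining value is a limit, (the limit of > 100000 nM in this assay, at which 1 of the 3 values shown sits), so compound 3 cannot be placed exactly.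

Compound 4 `CC[C@H](C(C)C)C(c1ccc(O)c(OC)c1)c1ccc(O)c(OC)c1` has not yet been measured in this assay. It differs from compound 1 in one place: hydrogen in place of propyl on a saturated chain carbon, four bonds along the chain from two aromatic carbons. Read one bond further out, the change is 1-isopropylhexyl to 1-isopropylpropyl.

Within the data shown here, two measured steps bear on this. Each also replaces the group on the saturated chain carbon bound to two aromatic carbons with a smaller one, and each raised the number: an 8.2-fold higher number from compound 1 to compound 2 (0.91 log units; beyond the scatter) and an at least 10-fold higher number from compound 1 to compound 3 (1.03 log units; beyond the scatter). The change to compound 4 is milder, keeping more of the original chain, so a smaller step in the same direction is expected. Compound 4 is therefore estimated at 30000 nM, with a likely range from 10000 nM to 100000 nM, meaning an expected 3.3-fold higher number from compound 1 to compound 4 (0.51 log units; beyond the scatter).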

Compound 4, half-maximal inhibitory concentration: 9700 nM
Compound 4: the middle estimate sits 3.1-fold (0.49 log units) above what was measured; the measured number lies below the stated range.
By their numbers in this assay, from the lowest: compounds 1 and 4 (each within the scatter of the next); then compound 2. At a limit, above all of these: compound 3.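

In this assay, the propyl part of the side chain can give way to hydrogen with no readable effect, and compounds 1 and 4 cannot be told apart: a 1.1-fold higher number from compound 1 to compound 4 (0.02 log units; within the scatter). A small group on the saturated chain carbon bound to two aromatic carbons is therefore compatible with a number in this range, so the higher numbers of compound 2 and compound 3 do not follow from a smaller group alone, as the steps to the 1-isopropylpropyl group show: a 7.7-fold lower number from compound 2 to compound 4 (0.89 log units; beyond the scatter), and an at least 10-fold lower number from compound 3 to compound 4 (1.01 log units; beyond the scatter). The second of these steps is only a floor, as compound 3 stands at a limit of the assay and not at a number: the limit of > 100000 nM in this assay, at which 1 of the 4 values shown sits.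

The compounds shown leave open whether a still shorter 1-isopropylethyl group or a longer chain such as 1-isopropyloctyl would stay in this range, and whether an amine or a carboxylic acid in place of the fluoro of compound 2 would give a number nearer to compound 4. They also leave open what a plain methyl in place of the isopropyl of compound 4 would do.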